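Replacing the phenyl group of compound 2

This account rests on a few compounds, and the source may have more. Where it says the series, first, only, none or still open, it means among the compounds named here.

compound 1 `CC(=O)c1ccc(-c2cccc(NC(=O)CCc3cccc4c3COB4O)c2)cc1` gives 48000 nM
compound 2 `CC(=O)c1ccc(-c2cccc(NC(=O)CCc3ccccc3)c2)cc1` gives 4000 nM

In a functional assay on HCT-116 cells (Homo sapiens) for antiproliferative activity, read by MTT assay, with a stated time of 72 h (a lower number here means a stronger inhibitor, a higher number a weaker inhibitor), compound 2 holds the lower of the two numbers at 4000 nM while compound 1 stands higher. Compound 3 `CC(=O)c1ccc(-c2cccc(NC(=O)CCc3cccc4c3C(O)OC4)c2)cc1` has yet to be measured. Its structure differs from that of compound 2 as follows: a group of 10 heavy atoms (8 carbon, 2 oxygen; one five-membered non-aromatic ring with 1 hetero atom, one six-membered aromatic ring of carbon only) in place of a group of 6 heavy atoms (6 carbon; one six-membered aromatic ring of carbon only), on a saturated chain carbon, two bonds along the chain from a carbonyl carbon so the phenyl gives way to a larger group with a five-membered non-aromatic ring with 1 hetero atom. Among the measured compounds shown here, one measured step bears on this: a 12-fold lower number from compound 1 to compound 2 (1.08 log units; beyond the scatter) where phenyl took the place of a group of 10 heavy atoms. Compound 3 brings back a group of that size, with no boron in it. For the measured compounds named here, with compound 1 at 48000 nM as the only guide to such a group, a higher number is expected for compound 3. The expected change is a 6.3-fold higher number from compound 2 to compound 3 (0.80 log units; beyond the scatter) and it remains an estimate. For compound 3 the estimated value is 25000 nM (expected range 7000 nM to 80000 nM).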

Compound 3, half-maximal inhibitory concentration: 18000 nM
Beside the measured number, compound 3's estimate is 1.4-fold (0.14 log units) above it; measured number inside the range.
By their numbers in this assay, from the lowest: compound 2; then compound 3; then compound 1.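

In this assay, a 4.5-fold higher number from compound 2 to compound 3 (0.65 log units; beyond the scatter) shows that the phenyl on this saturated chain carbon can give way to a larger group with no boron in it and still end with a higher number, so the rise seen with compound 1 does not need boron. The exchange between the two larger groups, a 2.7-fold lower number from compound 1 to compound 3 (0.43 log units; beyond the scatter), shows that the group with the five-membered non-aromatic ring with 1 hetero atom still differs from the boron-containing group, though neither reaches the number of compound 2. Nothing measured here explains either step.

Going by these compounds, what stays open is whether a small substituent on the phenyl itself, such as a hydroxymethyl or a methoxy group, would leave the number of compound 2 in place. Equally open, on these data alone, is how an amine, a carboxylic acid or a longer chain at this carbon would read.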